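A few compounds are considered here, and "the series" means these few. Any claim that something is new, unique, unknown or untested is made for them only; others in the source may bear on it.

Series values in a functional assay on HeLa cells (Homo sapiens) for antiproliferative activity, with a stated time of 48 h; on this read-out higher numbers stand for weaker inhibition and lower numbers for stronger inhibition:

- compound 1 `C=C(Br)C(=O)Nc1ccc(C(=O)/C=C/c2cc(OC)c(OC)c(OC)c2)cc1`: 420 nM
- compound 2 `COc1cccc(/C=C/C(=O)c2ccc(N)cc2)c1`: 19000 nM
- compound 3 `COc1cc(/C=C/C(=O)c2ccc(N)cc2)cc(OC)c1`: 7900 nM
- compound 4 `COc1cc(/C=C/C(=O)c2ccc(N)cc2)cc(OC)c1OC`: not yet measured

Compound 3, at 7900 nM, holds the second highest of the three numbers. Compound 2 lies higher at 19000 nM, and compound 1 lies lower at 420 nM.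

The step to compound 4 is methoxy in place of hydrogen on an aromatic carbon. It is methoxy in place of hydrogen on an aromatic carbon, ortho to two methoxy groups and para to a large group.

Going by the values given here, one measured step bears on this change: a 2.4-fold lower number from compound 2 to compound 3 (0.38 log units; beyond the scatter). Among the compounds with values here, it is the same kind of exchange, modest in size, but no step has been measured at this particular place, so it is only a rough guide. Within the data shown here, compound 1 is joined to neither of the other measured compounds by a single-place step, so it only marks the low end of the numbers so far.

A second modest move toward a lower number is therefore expected in this assay, though a result within the scatter would not surprise. The expected change is a 2.5-fold lower number from compound 3 to compound 4 (0.39 log units; beyond the scatter). For compound 4 the estimated value is 3200 nM, with an expected range of 1100 nM to 8000 nM.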

Compound 4, half-maximal inhibitory concentration: 6900 nM
Estimate against measurement, compound 4: 2.2-fold (0.33 log units) below; the measured number falls inside the stated range.
By their numbers in this assay, from the lowest: compound 1; then compounds 4 and 3 (each within the scatter of the next); then compound 2.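

In this assay, adding a methoxy group to the aromatic carbon that is ortho to two methoxy groups and para to a large group gives a 1.1-fold lower number from compound 3 to compound 4 (0.06 log units; within the scatter), which is within the scatter, whereas the earlier methoxy exchange at another place gave a 2.4-fold lower number from compound 2 to compound 3 (0.38 log units; beyond the scatter), beyond the scatter, so that earlier step does not carry over to this position. With the methoxy pattern the same at both ends, hydrogen in place of (1-bromoethenyl)carbonyl on the nitrogen gives a 16-fold higher number from compound 1 to compound 4 (1.22 log units; beyond the scatter), so among the steps now in hand the large change sits at the nitrogen and not on the methoxy-bearing ring. No measurement here accounts for either step.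

As far as these compounds go, it remains open which part of the (1-bromoethenyl)carbonyl group goes with the large step, since a plain ethenylcarbonyl without bromine or a simple acetyl on the same nitrogen would be needed to separate the bromine, the double bond and the carbonyl. From the compounds shown here alone, it is also open whether this methoxy exchange stays within the scatter when the nitrogen carries the (1-bromoethenyl)carbonyl group rather than hydrogen.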